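Working notes: chloro in place of methoxy

The source may report more compounds than this note shows. Statements on the series, on what has been measured and on what is new or still open speak of the compounds shown alone.

In a physicochemical assay for lipophilicity (on this read-out higher numbers stand for higher lipophilicity and lower numbers for lower lipophilicity), the measured compounds stand as follows
- compound 1 `Cc1cccc(C2=NC(c3ccccc3)CO2)c1` gives 4.11
- compound 2 `COc1cccc(C2=NC(c3ccccc3)CO2)c1` gives 3.77

Compound 2 holds the lower of the two numbers. Compound 3 `Clc1cccc(C2=NC(c3ccccc3)CO2)c1` is unmeasured and differs from it by chloro in place of methoxy on an aromatic carbon in the shared core. Among the compounds with values here, one measured step bears on this change, methoxy in place of methyl, which gave a number 0.34 log units lower from compound 1 to compound 2 (beyond the scatter) and counts as modest. That step involves no chloro, so it guides the expectation only loosely. Methoxy leaves here, so a modest rise in this assay is expected. The expected step is a number 0.53 log units higher from compound 2 to compound 3 (beyond the scatter) and remains an estimate. Estimated for compound 3 is 4.3 within 4 to 4.6 as the expected range.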

Compound 3, partition coefficient: 4.44
Beside the measured number, compound 3's estimate is 0.14 log units below it; the range from low to high includes it.
By their numbers in this assay, from the lowest: compound 2; then compound 1; then compound 3.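

In this assay chloro in place of methoxy gives a number 0.67 log units higher from compound 2 to compound 3 (beyond the scatter) and chloro in place of methyl gives a number 0.33 log units higher from compound 1 to compound 3 (beyond the scatter) at this same place on an aromatic carbon. Both steps lie beyond the scatter, so compound 3 stands highest of the three, and the order at this position runs from methoxy through methyl to chloro. Nothing measured alongside these numbers accounts for that order.

Where an amine, a carboxylic acid or a longer chain would fall at this place remains open. So does whether the same order holds elsewhere on the shared core.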